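A 4-Fluorophenyl Group in Place of Furan-2-yl

This account rests on a few compounds, and the source may have more. Where it says the series, first, only, none or still open, it means among the compounds named here.

In a functional assay on SW620/5-FU cells (Homo sapiens) for cytotoxicity, read by MTT assay, with a stated time of 48 h, in the presence of a further agent that is not named here (on this read-out higher numbers stand for an effect only at larger amounts of compound and lower numbers for an effect already at smaller amounts), compound 1 `Cc1nn(C)c2nc(NNC(=O)Nc3cc(Cl)nc(Cl)c3)cc(-c3ccco3)c12` is recorded at > 100000 nM, which is a limit of the assay and not a number. Its exact position is therefore unknown. Compound 2 `CCCCOc1cc(NC(=O)NNc2cc(-c3ccc(F)cc3)c3cnn(C)c3n2)cc(Cl)n1`, which also carries a 4-fluorophenyl group, gives a true number of 29300 nM. Compound 3 `Cc1nn(C)c2nc(NNC(=O)Nc3cc(Cl)nc(Cl)c3)cc(-c3ccc(F)cc3)c12` keeps the core and urea side of compound 1 but has 4-fluorophenyl in place of furan-2-yl on an aromatic carbon. Within the data shown here, no measured pair isolates this change, so the expectation rests only on the value of compound 2 at 29300 nM. A modest move toward effect at smaller amounts is expected in this assay, estimated as an at least 2.0-fold lower number from compound 1 to compound 3 (0.30 log units; that floor lies within the scatter). Compound 3 may also reach the limit of the assay. For compound 3 the expected value is 50000 nM, with an estimated range from 15000 nM to 100000 nM.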

Compound 3, half-maximal effective concentration: 17400 nM
Compound 3: middle estimate off by 2.9-fold (0.46 log units), on the high side; the measured number falls inside the stated range.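

In this assay, among these compounds, this is the first comparison that isolates this position: with the shared core and urea side held fixed, 4-fluorophenyl in place of furan-2-yl on an aromatic carbon gives an at least 5.7-fold lower number from compound 1 to compound 3 (0.75 log units; beyond the scatter). The group at this position, opposite the ring nitrogen, therefore bears on the read-out, and the exchange yields a true number from a starting point that had none. The size of the step remains a floor because compound 1 stands at a limit of the assay and not at a number: the limit of > 100000 nM in this assay, at which 1 of the 3 values shown sits.

The compounds shown leave open how a plain phenyl group at this position would read, and so whether the fluorine or the six-membered ring carries the step. From the compounds shown here alone, how an amine or a longer chain at this position would read also remains open.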